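The source may hold more compounds than are shown below. What is called first, only, known or untested is meant among the compounds shown, and "the series" means these compounds.

Three compounds share one core and carry the same bromo group. Compound 1 `Cc1[nH]c2ccccc2c(=O)c1Br` reads > 20000 nM in a physicochemical assay for solubility, read by HPLC, at pH 7.4 (a higher number here means a more soluble compound, a lower number a less soluble compound), which is a limit of the assay. Compound 2 `Cc1[nH]c2ccc(Br)cc2c(=O)c1Br` reads > 20000 nM, also a limit. Within the data shown here, compound 3 `Cc1[nH]c2ccc(Cl)cc2c(=O)c1Br`, at 5000 nM, is the only one with an actual number in this assay.

Compound 4 `CCCCC#Cc1c(C)[nH]c2ccc(Cl)cc2c1=O` now changes compound 3 at the bromo itself: hex-1-yn-1-yl in place of bromo on an aromatic carbon. All three measured compounds keep that bromo. Among the measured compounds shown here, no measured step touches this carbon, and the evidence is indirect. Two steps can be read: an at least 4.0-fold lower number from compound 1 to compound 3 (0.60 log units; beyond the scatter) and an at least 4.0-fold lower number from compound 2 to compound 3 (0.60 log units; beyond the scatter). Both are chloro changes elsewhere on the core. The third, a step that the two limits leave unreadable from compound 1 to compound 2, cannot be sized. Taking those two readable steps as the only guide to size, a further fall of similar modest size is expected from the number of compound 3. The expected step is a 4.2-fold lower number from compound 3 to compound 4 (0.62 log units; beyond the scatter). For compound 4 the estimated value is 1200 nM, with an expected range from 200 nM to 6000 nM.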

Compound 4, solubility: 2000 nM
Estimate against measurement, compound 4: 1.7-fold (0.22 log units) below, and the stated range covers the measured number.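

Among these compounds, compound 4 is the first with a change at the carbon that holds the bromo in the earlier compounds, which differ only at another place on the shared core. In this assay, the change gives a 2.5-fold lower number from compound 3 to compound 4 (0.40 log units; beyond the scatter), so this carbon, ortho to a methyl group and two atoms from the ring nitrogen, is one where the read-out moves. Even with hex-1-yn-1-yl, 6 heavy atoms against 1 for bromo, the fall stays modest and compound 4 still gives a real number, 2000 nM.

The compounds shown leave open how an amine or a carboxylic acid would read at this carbon in place of hex-1-yn-1-yl. The step between compound 1 and compound 2 cannot be read, as both values are limits: the limit of > 20000 nM in this assay, at which 2 of the 4 values shown sit.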